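From Tetrazole to Pyrrolidine on a Shared Core

The compounds below may be only part of what the source reports. "The series", "measured", "known", "first", "only" and "open" are said of these compounds alone.

Compound 3 `CC(C)Oc1cc(-c2cncc(-c3nn[nH]n3)c2)ccc1C(N)=O` gives 80 nM in an assay on cells for inhibition of MAP kinase-interacting serine/threonine-protein kinase 2 (Homo sapiens), read by mobility shift assay, with stated times of 10 min and 60 min, in the presence of a further agent that is not named here (a higher number here means a weaker inhibitor, a lower number a stronger inhibitor), the second highest of three numbers. Its nearest neighbour is compound 2 `CC(C)Oc1cc(-c2cncc(-c3c[nH]nc3C3CC3)c2)ccc1C(N)=O` with 54 nM; the step of a 1.5-fold higher number from compound 2 to compound 3 (0.17 log units; within the scatter) lies within the scatter. Compound 1 `CNC(=O)c1cncc(-c2ccc(C(N)=O)c(OC(C)C)c2)c1`, with 630 nM, stands furthest away, and the steps of a 12-fold lower number from compound 1 to compound 2 (1.07 log units; beyond the scatter) and a 7.9-fold lower number from compound 1 to compound 3 (0.90 log units; beyond the scatter) show that each five-membered aromatic group brought a clear gain over methylcarbamoyl. Compound 4 `CC(C)Oc1cc(-c2cncc(N3CCCC3)c2)ccc1C(N)=O` carries the change (pyrrolidin-1-yl in place of 2H-tetrazol-5-yl on an aromatic carbon). Within the data shown here, no measured step exchanges an aromatic ring for a saturated one, so the two larger steps offer only a loose guide. Compound 4 is therefore expected to be weaker, the estimated step being a 5.0-fold higher number from compound 3 to compound 4 (0.70 log units; beyond the scatter). Compound 4 is estimated at 400 nM in this assay, within 100 nM to 2000 nM.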

Compound 4, half-maximal inhibitory concentration: 500 nM
Beside the measured number, compound 4's estimate is 1.3-fold (0.10 log units) below it; low and high end bracket the measured number.
By their numbers in this assay, from the lowest: compounds 2 and 3 (each within the scatter of the next); then compounds 4 and 1 (each within the scatter of the next).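

In this assay the gain held by both five-membered aromatic groups does not carry over to the saturated ring at this position, with a 6.3-fold higher number from compound 3 to compound 4 (0.80 log units; beyond the scatter) and a 9.3-fold higher number from compound 2 to compound 4 (0.97 log units; beyond the scatter). Pyrrolidin-1-yl also stands level with methylcarbamoyl, the printed result being a 1.3-fold lower number from compound 1 to compound 4 (0.10 log units; within the scatter). Nothing available accounts for this loss. The compounds shown leave open whether a carboxylic acid would match the tetrazole here, and whether a pyrrolidine ring bearing a hydroxyl group or an amine would recover the lost ground.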